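The source may hold more compounds than are shown below. What is called first, only, known or untested is meant among the compounds shown, and "the series" means these compounds.

In an ADME assay on Caco-2 cells (Homo sapiens) for permeability, read by LC-MS, in the apical to basolateral direction, with a stated time of 60 min, at pH 6.5 (a higher number here means that the compound crosses the layer faster, a lower number that the compound crosses the layer more slowly), compound 1 `O=C(NCc1cc(Cl)ccc1-n1cnnn1)[C@@H]1C[C@@H]2C[C@@H]2N1C(=O)[C@H](O)CC1CC1` gives 3.6 10^-6 cm/s and compound 2 `O=C(NCc1cc(Cl)ccc1-n1cnnn1)[C@@H]1C[C@H]2C[C@H]2N1C(=O)[C@H](O)CC1CC1` gives 6.9 10^-6 cm/s. The step between them is a 1.9-fold higher number from compound 1 to compound 2 (0.28 log units; within the scatter), and what separates them is the fact that compounds 1 and 2 differ only in the configuration as drawn. Compound 2 therefore cannot be told apart from compound 1 on these two numbers. Compound 3 `CCCC[C@@H](O)C(=O)N1[C@@H]2C[C@@H]2C[C@H]1C(=O)NCc1cc(Cl)ccc1-n1cnnn1` alters a side chain of compound 2: propyl in place of cyclopropyl on a saturated chain carbon, two bonds along the chain from a carbonyl carbon and an oxygen on a saturated carbon. In words, this is propyl in place of cyclopropyl on a saturated chain carbon, two bonds along the chain from a carbonyl carbon and an oxygen on a saturated carbon. For the measured compounds named here, the one measured step changes configuration only and does not touch this group, so it gives no direct guide. Starting from compound 2 at 6.9 10^-6 cm/s, no step beyond the scatter is expected in this assay. The estimated step is a 1.0-fold higher number from compound 2 to compound 3 (0.01 log units; within the scatter). For compound 3 the expected value is 7 10^-6 cm/s, within an estimated range of 3 10^-6 cm/s to 15 10^-6 cm/s.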

Compound 3, apparent permeability: 35 10^-6 cm/s
Beside the measured number, compound 3's estimate is 5.0-fold (0.70 log units) below it, and the stated range ends below it.
By their numbers in this assay, from the lowest: compounds 1 and 2 (each within the scatter of the next); then compound 3.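

In this assay, the side chain on this saturated chain carbon proves to be a place where a small edit counts: going to propyl in place of cyclopropyl gives a 5.1-fold higher number from compound 2 to compound 3 (0.71 log units; beyond the scatter). For the compounds shown here, the only earlier step changed configuration alone and stayed within the scatter, so this is the first change beyond it, and it comes from a swap in which the heavy-atom count, the carbon count and the absence of hydrogen-bond donors, acceptors and charge all stay the same, while the three-membered ring is lost. Nothing in hand explains why this one change has an effect of this size.

As far as these compounds go, this is a single pair, so it is open whether a longer chain such as pentyl, or a branched one such as isopropyl, would follow propyl or fall back towards cyclopropyl. From the compounds shown here alone, it is also open whether the same swap on the configuration of compound 1 would give a step of similar size.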